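Amino in place of methyl on a carbonyl carbon

The compounds below may be only part of what the source reports. "The series", "measured", "known", "first", "only" and "open" are said of these compounds alone.

In a functional assay on Bel-7402 cells (Homo sapiens) for cytotoxicity, read by resazurin assay, with a stated time of 72 h (a higher number here means a weaker inhibitor, a lower number a stronger inhibitor), two compounds have readings so far. Compound 1 `N#CCCSC(=S)NCc1cnc2ccccc2c1` gives 96400 nM in this test. Compound 2 `CC(=O)CCSC(=S)NCc1cccnc1` gives 3430 nM and holds the lower of the two numbers, with the gap beyond the usual scatter. Going by the values given here, these two compounds differ in more than one place, so they offer no single-change step as a guide. Compound 3 `NC(=O)CCSC(=S)NCc1cccnc1` departs from compound 2 by one change amino in place of methyl on a carbonyl carbon that turns acetyl into carbamoyl. Among the compounds with values here, no measured pair shows this change, so only a small move towards a higher number is expected in this assay at a size near the scatter. The estimated step is a 1.5-fold higher number from compound 2 to compound 3 (0.16 log units; within the scatter) and no more is claimed for it. For compound 3 the expected value is 5000 nM with an estimated range from 1700 nM to 15000 nM in repeat measurements.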

Compound 3, half-maximal inhibitory concentration: 3330 nM
For compound 3 the middle estimate is 1.5-fold (0.18 log units) above the measured one, and the stated range covers the measured number.
By their numbers in this assay, from the lowest: compounds 3 and 2 (each within the scatter of the next); then compound 1.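

In this assay amino in place of methyl on a carbonyl carbon gives a 1.0-fold lower number from compound 2 to compound 3 (0.01 log units; within the scatter) and so provides the first single-change step among these compounds. At this place, acetyl and carbamoyl cannot be told apart by this read-out, although the change brings in a hydrogen-bond donor that methyl does not carry. Nothing on hand offers a reason for this result.

The compounds shown leave open whether a carboxylic acid or a methyl ester at the same carbonyl carbon would also read level with compound 2 and compound 3, or whether a longer chain in place of the 2-carbamoylethyl group would shift the number. They also leave open whether the same change would read alike on the core of compound 1.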